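A few compounds are considered here, and "the series" means these few. Any claim that something is new, unique, unknown or untested is made for them only; others in the source may bear on it.

Measured so far:
Compound 1 `CN(C)c1nc(N)sc1C(=O)c1cnc2ccccn12`: 32%
Compound 2 `Cc1nc(N)sc1C(=O)c1cnc2ccccn12`: 53%

Both numbers come from a functional assay on the whole organism (strain Sprague-Dawley) for inhibition, with Rattus norvegicus as the target, read by paw edema, with stated times of 1 h and 3 h, at a dose of 50 mg/kg by the oral route; on this read-out higher numbers stand for more inhibition at the one dose given (going by the name of the read-out) and lower numbers for less inhibition. Among the compounds with values here, compound 2 stands highest of the two, and its only neighbour, compound 1, sits lower by a step beyond the scatter, a number 21 percentage points higher from compound 1 to compound 2 (beyond the scatter). Compound 3 `Nc1ncc(C(=O)c2cnc3ccccn23)s1` has not yet been measured. It differs from compound 2 in one place: hydrogen in place of methyl on an aromatic carbon. Within the data shown here, the single measured step, a number 21 percentage points higher from compound 1 to compound 2 (beyond the scatter), replaced one group with another rather than removing a group altogether, so it offers only indirect guidance for the present change. With no closer comparison, the expectation is a small move in this assay, more likely downward than upward, but not clearly beyond the scatter. Compound 3 is therefore estimated to give 45% in this assay, with a range from 25% to 65%. This estimate corresponds to an expected step of a number 8 percentage points lower from compound 2 to compound 3 (within the scatter).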

Compound 3, a percentage reported as inhibition, in the whole organism at one dose (the size of the read-out at that dose, not a potency): 33%
Compound 3: the middle estimate sits 12 percentage points above what was measured; low and high end bracket the measured number.
By their numbers in this assay, from the lowest: compounds 1 and 3 (each within the scatter of the next); then compound 2.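

In this assay the methyl on this aromatic carbon of the five-membered ring proves to count for something: putting hydrogen in its place gives a number 20 percentage points lower from compound 2 to compound 3 (beyond the scatter), so a single carbon atom is enough for a step beyond the scatter. Dimethylamino and hydrogen at this place cannot be told apart, with a number 1 percentage points higher from compound 1 to compound 3 (within the scatter), so among these three groups only methyl stands apart, and a larger group here does not simply carry the effect further. Nothing available explains why methyl differs from the other two groups.

From the compounds shown here alone, what remains open is whether the effect is particular to methyl or is shared by a longer chain such as ethyl, or by a halogen such as chlorine or an ether such as methoxy. Also open, going by these compounds, is whether the same pattern would hold if the rest of the shared core were changed.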